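Swapping a Piperazine for a Piperidine on the Core

The source may hold more compounds than are shown below. What is called first, only, known or untested is meant among the compounds shown, and "the series" means these compounds.

Compound 1 `Cc1ccc2ncc(S(=O)(=O)c3ccc(Cl)cc3)c(N3CCC(C)CC3)c2c1` and compound 2 `CCN1CCN(c2c(S(=O)(=O)c3ccccc3)cnc3ccccc23)CC1` share a core carrying a phenylsulfonyl group and a saturated ring. In an assay on isolated protein for displacement of a labelled ligand from metabotropic glutamate receptor 5 (Homo sapiens), with a stated time of 60 min, tested at 1 uM (a higher number here means more inhibition at the concentration tested (going by the name of the read-out), a lower number less inhibition), compound 1 gives 79%, whereas compound 2 gives 1.7%, the lowest of the two numbers and a gap beyond the scatter. Compound 3 `O=S(=O)(c1ccccc1)c1cnc2ccccc2c1N1CCCCC1` has not been measured. It differs from compound 2 in one place: piperidin-1-yl in place of 4-ethylpiperazin-1-yl on an aromatic carbon. A rise is expected from compound 2 to compound 3, of the size a number 43.3 percentage points higher from compound 2 to compound 3 (beyond the scatter), because compound 1 gives 79% with a related saturated ring. In this assay compound 3 is estimated at 45%, within 10% to 85%.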

Compound 3, a percentage reported as inhibition, at one concentration (the size of the read-out at that concentration, not a potency): 71.4%
Estimate against measurement, compound 3: 26.4 percentage points below, and the stated range covers the measured number.
By their numbers in this assay, from the lowest: compound 2; then compounds 3 and 1 (each within the scatter of the next).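

In this assay piperidin-1-yl in place of 4-ethylpiperazin-1-yl on this aromatic carbon gives a number 69.7 percentage points higher from compound 2 to compound 3 (beyond the scatter) and leaves the rest of the molecule unchanged. Within the data shown here, the earlier pair differed in more than one place, so this is the first reading of the change in this saturated ring alone. Nothing available explains the step. The compounds shown do not separate the second ring nitrogen from the ethyl group as the part that matters. A morpholine ring or a piperazine ring without the ethyl group at this position would help tell them apart.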